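The compounds below may be only part of what the source reports. "The series", "measured", "known", "first", "only" and "open" are said of these compounds alone.

Measured in an assay on cells for inhibition of Palmitoleoyl-protein carboxylesterase NOTUM variant C330S (Homo sapiens), read by fluorescence, with a stated time of 40 min; on this read-out higher numbers stand for weaker inhibition and lower numbers for stronger inhibition:
compound 1 `Cc1cc(C(=O)O)c(C)n1-c1ccc(Cl)c(C(F)(F)F)c1`: 2100 nM
compound 2 `Cc1cc(C(=O)O)c(C)n1-c1ccc(Cl)c(Cl)c1`: 270 nM
compound 3 `COCCNC(=O)C1CCN(c2ccc(Cl)c(C(F)(F)F)c2)C1`: 3500 nM

Compound 3 gives the highest of the three numbers in this assay. Its gap to compound 1 lies within the scatter, whereas compound 2 sits well below it, beyond the scatter. For the measured compounds named here, the only step between compounds that differ in one place, a 7.8-fold lower number from compound 1 to compound 2 (0.89 log units; beyond the scatter), concerns the substituent on the aromatic ring and leaves the amide untouched.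

Compound 4 `O=C(C1CCN(c2ccc(Cl)c(C(F)(F)F)c2)C1)N1CC2COCC2C1` differs from compound 3 at the amide: a group of 8 heavy atoms (6 carbon, 1 nitrogen, 1 oxygen; 2 five-membered non-aromatic rings with 1 hetero atom each) in place of a group of 5 heavy atoms (3 carbon, 1 nitrogen, 1 oxygen; no ring), on a carbonyl carbon. Going by the values given here, no measured pair in this set changes that part of the molecule, so there is nothing to scale the step against, and the one known step, a 7.8-fold lower number from compound 1 to compound 2 (0.89 log units; beyond the scatter), sits on a different part of the shared core and does not carry over. For compound 4 the working expectation in this assay is therefore no step beyond the scatter, a 1.4-fold lower number from compound 3 to compound 4 (0.15 log units; within the scatter), with wide uncertainty in both directions. Compound 4 is thus estimated at 2500 nM with a range from 800 nM to 8000 nM.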

Compound 4, half-maximal inhibitory concentration: 3100 nM
Compound 4: middle estimate off by 1.2-fold (0.09 log units), on the low side, within the range that was stated.
By their numbers in this assay, from the lowest: compound 2; then compounds 1, 4 and 3 (each within the scatter of the next).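

In this assay, for the compounds shown here, this is the first measured pair that changes the group on the carbonyl carbon: a 1.1-fold lower number from compound 3 to compound 4 (0.05 log units; within the scatter). Here (2-methoxyethyl)amino, with 5 heavy atoms, no ring and 1 hydrogen-bond donor, gives way to a group of 8 heavy atoms, 2 five-membered non-aromatic rings and 0 hydrogen-bond donors, and the number stays within the scatter, so at this position and on this core the read-out does not separate the two groups. No supporting data bear on this result.

As far as these compounds go, it remains open whether chloro in place of trifluoromethyl also lowers the number on the amide compounds, as in a 7.8-fold lower number from compound 1 to compound 2 (0.89 log units; beyond the scatter). From the compounds shown here alone, how a carboxylic acid or a longer chain would read on this carbonyl carbon is also open.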